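A few compounds are considered here, and "the series" means these few. Any claim that something is new, unique, unknown or untested is made for them only; others in the source may bear on it.

Working notes on the series. In an ADME assay on the whole organism (plasma) for pharmacokinetics, with Rattus norvegicus as the target, at a dose of 5 mg/kg by the oral route (a higher number here means more compound in the circulation at the dose given, a lower number less compound in the circulation), compound 3 `CCC(CC)[C@@H]1C(=O)N[C@H](C2Cc3ccccc3C2)C(=O)N1[C@@H](C(=O)NC)c1ccc(C)nc1C` gives 1250 ng.h/mL and lies within the scatter of compound 1 `CCC(CC)[C@@H]1C(=O)N[C@H](C2Cc3ccccc3C2)C(=O)N1[C@@H](C(=O)N1CCOCC1)c1ccc(C)nc1` which gives 1380 ng.h/mL on the same read-out. Compound 2 `CC[C@H](C)[C@@H]1C(=O)N[C@H](C2Cc3ccccc3C2)C(=O)N1[C@@H](C(=O)N(C)C)c1ccc(C)[n+]([O-])c1` at 24 ng.h/mL stands far lower than compound 3, a gap well beyond the scatter.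

The step under review leads from compound 3 to compound 4 `CCC(CC)[C@@H]1C(=O)N[C@H](C2Cc3ccccc3C2)C(=O)N1[C@@H](C(=O)N1CCOCC1)c1ccc(C)nc1C` and places morpholin-4-yl in place of methylamino on a carbonyl carbon. For the measured compounds named here, no two measured compounds differ in one place only, so this change has no direct precedent.

The nearest guide is compound 1, which also carries morpholin-4-yl on a carbonyl carbon. Its value of 1380 ng.h/mL sits within the scatter of the value for compound 3, and that gives no reason to expect a large move in either direction. The expected outcome is therefore no step beyond the scatter in this assay and no firm direction. The estimated move is a 1.1-fold higher number from compound 3 to compound 4 (0.05 log units; within the scatter) and it is expected to stay small. The estimate for compound 4 is 1400 ng.h/mL with an expected range from 500 ng.h/mL to 3500 ng.h/mL in this read-out.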

Compound 4, area under the concentration-time curve: 2330 ng.h/mL
Compound 4: the middle estimate sits 1.7-fold (0.22 log units) below what was measured; measured number inside the range.
By their numbers in this assay, from the lowest: compound 2; then compounds 3, 1 and 4 (each within the scatter of the next).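

Working notes, continued. The series now has a direct reading of morpholin-4-yl in place of methylamino on a carbonyl carbon: in this assay the change gives a 1.9-fold higher number from compound 3 to compound 4 (0.27 log units; within the scatter) and so does not separate from the scatter, even though the entering group adds a six-membered ring and removes a hydrogen-bond donor. With morpholin-4-yl held on the carbonyl carbon, methyl in place of hydrogen on an aromatic carbon gives a 1.7-fold higher number from compound 1 to compound 4 (0.23 log units; within the scatter) in the same read-out, so this second change also leaves the number inside the scatter. Nothing on hand gives a reason for either step.

From the compounds shown here alone, whether other groups on the carbonyl carbon, such as piperidin-1-yl or a carboxylic acid in place of the amide, or an ethyl or a fluorine in place of the methyl on the aromatic carbon, would move the number beyond the scatter remains open. For the compounds shown here, compound 2 is joined to the other compounds by no single-place step, so these compounds do not show which of its differences goes with its low number.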